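Triazole aryl swap on a spirooxindole quinoxaline scaffold

The source may report more compounds than this note shows. Statements on the series, on what has been measured and on what is new or still open speak of the compounds shown alone.

Compound 1, `COc1ccc(-n2nncc2CN2C(=O)C3(C(C#N)=C(N)Oc4c3c3nc5ccccc5nc3c3ccccc43)c3ccccc32)cc1`: in a functional assay on A549 cells (Homo sapiens) for antiproliferative activity, read by MTT assay, with a stated time of 48 h (a lower number here means a stronger inhibitor, a higher number a weaker inhibitor), compound 1 gives only a limit, > 50000 nM.
Compound 2, `N#CC1=C(N)Oc2c(c3nc4ccccc4nc3c3ccccc23)C12C(=O)N(Cc1cnnn1-c1ccc(S(N)(=O)=O)cc1)c1ccccc12`: in this assay compound 2 likewise gives only a limit, > 50000 nM.

Compound 2 stands at the limit of this assay, and no number for it is known. Among the compounds with values here, the only other measured compound, compound 1, sits at the same limit, so the step that the two limits leave unreadable from compound 1 to compound 2 cannot be read in either direction; both values rest on (the limit of > 50000 nM in this assay, at which 2 of the 2 values shown sit).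

Compound 3, `Cc1ccc(-n2nncc2CN2C(=O)C3(C(C#N)=C(N)Oc4c3c3nc5ccccc5nc3c3ccccc43)c3ccccc32)c(C)c1`, differs from compound 2 in one place: 2,4-dimethylphenyl in place of 4-sulfamoylphenyl on an aromatic nitrogen. The change removes the sulfamoyl group and puts two methyl groups on the phenyl ring attached to the triazole nitrogen. Within the data shown here, the single measured step, from methoxy to sulfamoyl, is not readable, so it gives no guide to the size or direction of the present change. With both measured compounds at the limit, compound 3 is expected to remain at or near that limit, and the step of a number no higher from compound 2 to compound 3 (the limit leaves the size open) is estimated as none that can be read. For compound 3 the expected value in this assay is 50000 nM, within a range from 10000 nM to 200000 nM, with a strong chance that only a limit is reported again.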

Compound 3, half-maximal inhibitory concentration: > 50000 nM
Compound 3 gave a limit, no number; the forecaster's own chance of this, stated with the estimate: 70%; the middle value lies on the limit itself.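

In this assay compound 3 gives > 50000 nM, which is a limit and not a number. The steps linking compound 3 to compound 1 and compound 2 therefore cannot be read, because all three compounds rest on the same limit: the limit of > 50000 nM in this assay, at which 3 of the 3 values shown sit.

The compounds shown leave open how far each lies beyond that limit, and whether the aryl group on the aromatic nitrogen has any bearing on the result in this assay.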